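This account rests on a few compounds, and the source may have more. Where it says the series, first, only, none or still open, it means among the compounds named here.

Measured so far in a functional assay on K562 cells (Homo sapiens) for inhibition; on this read-out lower numbers stand for stronger inhibition and higher numbers for weaker inhibition: compound 1 `O=C1C=CC(OCC(F)(F)F)N1c1ccc(C(F)(F)F)cc1` gives 13100 nM; compound 2 `O=C1C=CC(OCC(F)(F)F)N1c1ccccc1` gives 24600 nM.

Compound 2 stands highest of the two numbers in this assay; the nearest, compound 1, is separated only by the step of a 1.9-fold higher number from compound 1 to compound 2 (0.27 log units; within the scatter), which is within the scatter. Compound 3 `O=C1C=CC(OCC(F)(F)F)N1c1ccccc1F` differs from compound 2 by fluoro in place of hydrogen on an aromatic carbon. Going by the values given here, the single measured step, a 1.9-fold higher number from compound 1 to compound 2 (0.27 log units; within the scatter), concerns a different group on the same aromatic ring and no measured step covers a fluoro entering. For compound 3 the expected step is therefore a 1.2-fold lower number from compound 2 to compound 3 (0.09 log units; within the scatter), nothing beyond the scatter. Compound 3 is estimated at 20000 nM, range 8000 nM to 60000 nM.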

Compound 3, half-maximal inhibitory concentration: 12000 nM
Estimate against measurement, compound 3: 1.7-fold (0.22 log units) above; low and high end bracket the measured number.
By their numbers in this assay, from the lowest: compounds 3, 1 and 2 (each within the scatter of the next, the first and the last beyond it).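

In this assay, going by these compounds alone, fluoro in place of hydrogen on an aromatic carbon ortho to a large group gives a 2.1-fold lower number from compound 2 to compound 3 (0.31 log units; beyond the scatter) and this modest step is the first printed as beyond the scatter. A single added fluorine at this position is thus enough to move the read-out measurably, though only just past the scatter. No available evidence bears on why this change has this effect. Still open, going by these compounds, is whether a larger substituent at this position, such as chloro, methoxy or an amine, moves the number in the same direction as fluoro. Also open, on these data alone, is whether the gain from fluoro persists alongside a trifluoromethyl group on the same ring.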